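The source may report more compounds than this note shows. Statements on the series, on what has been measured and on what is new or still open speak of the compounds shown alone.

Compound 1 `COc1ccccc1Nc1nc(SCc2ccc(C(F)(F)F)cc2)nc2ccccc12`: in a functional assay on MGC-803 cells (Homo sapiens) for cytotoxicity, read by MTT assay, with a stated time of 72 h (on this read-out higher numbers stand for weaker inhibition and lower numbers for stronger inhibition), compound 1 sits at the assay limit of > 50000 nM.
Compound 2 `FC(F)(F)c1ccc(CSc2nc(Nc3cccc(C(F)(F)F)c3)c3ccccc3n2)cc1`: compound 2 gives 15100 nM in this assay.
Compound 3 `COc1ccc(Nc2nc(SCc3ccc(C(F)(F)F)cc3)nc3ccccc23)cc1`: compound 3 gives 13800 nM in this assay.

All three share one core and differ only in the aryl group on the nitrogen. Compound 3 holds the lowest of the two real numbers, but the gap between these two is only a 1.1-fold lower number from compound 2 to compound 3 (0.04 log units; within the scatter), so the two cannot be told apart. Compound 1 reports only a limit (the limit of > 50000 nM in this assay, at which 1 of the 3 values shown sits).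

Compound 4 `COc1ccc(Nc2nc(SCc3ccc(C(F)(F)F)cc3)nc3ccccc23)c(OC)c1` is the next step: methoxy in place of hydrogen on an aromatic carbon. It keeps the 4-methoxy group of compound 3 and adds a second methoxy where compound 1 carries its only one. The step that bears on it is an at least 3.6-fold lower number from compound 1 to compound 3 (0.55 log units; beyond the scatter), a move away from the 2-methoxy pattern that brought the number down from a limit to a measured value. Returning a methoxy to that position, with the 4-methoxy kept, is therefore expected to push the number back up by a 1.8-fold higher number from compound 3 to compound 4 (0.26 log units; within the scatter), though how far a second methoxy shifts things when one is already present is untested here. Compound 4 is estimated at 25000 nM, likely between 9000 nM and 60000 nM, with some chance of a limit.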

Compound 4, half-maximal inhibitory concentration: > 50000 nM
Compound 4: no number, only a limit; the forecaster's own chance of this, stated with the estimate: 30%; middle value at least 2.0-fold (0.30 log units) away from the limit.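

Changing the 4-methoxyphenyl group to 2,4-dimethoxyphenyl gives an at least 3.6-fold higher number from compound 3 to compound 4 (0.55 log units; beyond the scatter) in this assay. This isolates what the earlier comparison could not, since the step between compound 1 and compound 3 changed where a single methoxy sat, whereas here the 4-methoxy group stays and a methoxy on the carbon ortho to a large group is simply added, and the number still rises; the comparison with another aryl group on the nitrogen points the same way, at an at least 3.3-fold higher number from compound 2 to compound 4 (0.51 log units; beyond the scatter). Compound 1 and compound 4, the two compounds with a methoxy in this place, both rest at a limit of the assay rather than at a number, so the step between them cannot be read: the limit of > 50000 nM in this assay, at which 2 of the 4 values shown sit.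

From the compounds shown here alone, how far past that limit either compound lies stays unknown, so the real size of the cost of this methoxy is open. Also open, going by these compounds, is whether the rise belongs to methoxy alone or to any group on this carbon, which a fluorine atom, a hydroxyl group or an amine in the same place would begin to answer.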